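The source may report more compounds than this note shows. Statements on the series, on what has been measured and on what is new or still open speak of the compounds shown alone.

Measured compounds:
- compound 1 `COc1ccc(-c2c(S(=O)(=O)c3cccc(C#N)c3)cnc3cc(F)ccc23)cc1` — 0.92 mL/min
- compound 2 `Cc1ccc(S(=O)(=O)c2cnc3cc(F)ccc3c2-c2ccc(F)cc2)cc1C` — 9.25 mL/min
- compound 3 `COc1ccc(-c2c(S(=O)(=O)c3ccc(F)cc3)cnc3cc(F)ccc23)cc1` — 1.77 mL/min

In an ADME assay on microsomes from liver (Homo sapiens) for metabolic stability, tested at 2.5 uM (a higher number here means faster removal of the compound, a lower number slower removal), compound 3 gives the second highest of the three numbers. Its nearest neighbour is compound 1: a 1.9-fold higher number from compound 1 to compound 3 (0.28 log units; within the scatter), so these two cannot be ordered. The furthest is compound 2, whose number sits well beyond the scatter from that of compound 3.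

Compound 4 `COc1ccc(-c2c(S(=O)(=O)c3ccc(C)c(C)c3)cnc3cc(F)ccc23)cc1` is not yet measured. Relative to compound 3 it carries 3,4-dimethylphenyl in place of 4-fluorophenyl on a sulfonyl sulfur.

Among the measured compounds shown here, only one measured step touches the group on the sulfonyl sulfur, a 1.9-fold higher number from compound 1 to compound 3 (0.28 log units; within the scatter), and it stayed within the scatter. For the measured compounds named here, compound 2 also carries 3,4-dimethylphenyl on the sulfonyl sulfur, but it differs from compound 4 in a second place as well, so no clean step exists; its two values with compound 3 merely show a large gap. Taken together, a rise in this assay beyond the scatter is expected for compound 4, a 2.8-fold higher number from compound 3 to compound 4 (0.45 log units; beyond the scatter), with wide uncertainty. The estimate for compound 4 is 5 mL/min, in the range 2 mL/min to 12 mL/min.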

Compound 4, intrinsic clearance in a liver preparation (reported as CLH), per the amount of preparation that the assay uses: 4.13 mL/min
The estimate for compound 4 lay 1.2-fold (0.08 log units) above the measured number; low and high end bracket the measured number.
By their numbers in this assay, from the lowest: compounds 1 and 3 (each within the scatter of the next); then compound 4; then compound 2.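

In this assay, the group on the sulfonyl sulfur now gives clean steps beyond the scatter: 3,4-dimethylphenyl in place of 4-fluorophenyl gives (a 2.3-fold higher number from compound 3 to compound 4 (0.37 log units; beyond the scatter)), and 3,4-dimethylphenyl in place of 3-cyanophenyl gives (a 4.5-fold higher number from compound 1 to compound 4 (0.65 log units; beyond the scatter)), whereas the earlier comparison of 4-fluorophenyl and 3-cyanophenyl stayed within the scatter. The second place also counts with 3,4-dimethylphenyl held constant: methoxy in place of fluoro on an aromatic carbon gives (a 2.2-fold lower number from compound 2 to compound 4 (0.35 log units; beyond the scatter)), so the sulfonyl group alone does not set the number for compound 2. Nothing available here accounts for either the rise or the fall.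

Open, on these data alone, is where a phenyl carrying a single methyl, an amine or a carboxylic acid on the sulfonyl sulfur would fall. As far as these compounds go, the methoxy and fluoro comparison rests on one pair, so its size with 4-fluorophenyl or 3-cyanophenyl on the sulfonyl sulfur also remains open.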